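The source may hold more compounds than are shown below. What is called first, only, known or untested is meant among the compounds shown, and "the series" means these compounds.

Measured compounds:
compound 1 `CCCS(=O)(=O)N1CCC(CNC(=O)C2CC2)(C(=O)N2CCOCC2)CC1` in an assay on isolated protein for inhibition of sodium- and chloride-dependent glycine transporter 1 (Homo sapiens) (on this read-out higher numbers stand for weaker inhibition and lower numbers for stronger inhibition), gives > 5000 nM
compound 2 `CCCS(=O)(=O)N1CCC(CNC(=O)c2ccc(Cl)cc2Cl)(C(=O)NCC)CC1` in this assay gives 517 nM

Compound 1 does not reach a number in this assay: its value is a limit of the assay, as the limit of > 5000 nM in this assay, at which 1 of the 2 values shown sits, records, and so its true position is open-ended. Compound 2 is the only one of the two with a measured number, and that number sits well inside the range of the assay.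

Compound 3 `CCCS(=O)(=O)N1CCC(CNC(=O)c2c(F)cccc2F)(C(=O)N2CCOCC2)CC1` is not yet measured. It differs from compound 1 by 2,6-difluorophenyl in place of cyclopropyl on a carbonyl carbon: in words, 2,6-difluorophenyl in place of cyclopropyl on a carbonyl carbon, with the rest of the shared core unchanged. Among the compounds with values here, no measured pair shows this exact exchange, so the size of the step has to be judged from what the two numbers show. Compound 2, which carries an aromatic ring on the corresponding carbonyl carbon, gives 517 nM in this assay. Compound 1 with its cyclopropyl does not reach a number in this assay. On that basis the step from compound 1 to compound 3 is expected to be toward stronger inhibition, an at least 2.5-fold lower number from compound 1 to compound 3 (0.39 log units; beyond the scatter), though how far is uncertain since compound 1 has no number. Compound 3 is expected to give about 2000 nM in this assay, within 500 nM to 8000 nM.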

Compound 3, half-maximal inhibitory concentration: 131 nM
Beside the measured number, compound 3's estimate is 15-fold (1.18 log units) above it; the whole stated range lies above it.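

In this assay, the exchange of cyclopropyl for 2,6-difluorophenyl on a carbonyl carbon gives an at least 38-fold lower number from compound 1 to compound 3 (1.58 log units; beyond the scatter). Within the data shown here, this is the first step on the shared core that can be read at this position, and it shows that the group on this carbonyl carbon can by itself carry a compound from no number to a measured one, here with compound 3 at 131 nM. The size of the step is open on one side, because the value of compound 1 is a limit of the assay and not a number: the limit of > 5000 nM in this assay, at which 1 of the 3 values shown sits.

Among these compounds, compound 2 differs from compound 3 in more than one place, so no step between those two can be read, and the part played by the group on the other carbonyl cannot be separated from that of the aromatic ring. Going by these compounds, how much of the change belongs to the aromatic ring and how much to its two fluorine atoms stays open, as does the standing of a plain phenyl, a pyridine ring or a longer alkyl chain on this carbonyl carbon.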